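Hydrazone series against monoamine oxidase B: thiophene replaces phenyl

The source may hold more compounds than are shown below. What is called first, only, known or untested is meant among the compounds shown, and "the series" means these compounds.

Compound 1 `C(=N/Nc1nc2ccccc2nc1Cc1ccccc1)\c1ccccc1` is the parent of this small set. In an assay on isolated protein for inhibition of Amine oxidase [flavin-containing] B (Homo sapiens), read by spectrophotometry (a higher number here means a weaker inhibitor, a lower number a stronger inhibitor), compound 1 gives 320000 nM, the second highest of the three numbers. Compound 2 `O=[N+]([O-])c1ccc(/C=N/Nc2nc3ccccc3nc2Cc2ccccc2)cc1` carries a nitro in place of hydrogen on an aromatic carbon and gives 960000 nM, a step of a 3.0-fold higher number from compound 1 to compound 2 (0.48 log units; beyond the scatter). Compound 3 `Brc1cccc(/C=N/Nc2nc3ccccc3nc2Cc2ccccc2)c1` carries a bromo in place of hydrogen on an aromatic carbon and gives 48000 nM, a step of a 6.7-fold lower number from compound 1 to compound 3 (0.82 log units; beyond the scatter). Between the two substituted analogues the step is a 20-fold lower number from compound 2 to compound 3 (1.30 log units; beyond the scatter).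

Compound 4 `Cc1ccsc1/C=N/Nc1nc2ccccc2nc1Cc1ccccc1` is unmeasured. It differs from compound 1 in one place: 3-methylthiophen-2-yl in place of phenyl on a carbon with a double bond to nitrogen. For the measured compounds named here, none of the measured steps replaces the whole aromatic ring on the carbon with a double bond to nitrogen by a different ring; the steps from compound 1 to compound 2 and from compound 1 to compound 3 only add a group to that ring, and the step from compound 2 to compound 3 exchanges two substituted phenyls. They show that changes at this position move the number in both directions by modest to large amounts, but give no direction for this particular exchange. A step of modest size, in either direction, is expected, and the estimate for compound 4 is therefore held close to compound 1 with a wide range: in this assay compound 4 is expected to give about 250000 nM, between 60000 nM and 900000 nM, meaning a step of a 1.3-fold lower number from compound 1 to compound 4 (0.11 log units; within the scatter).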

Compound 4, half-maximal inhibitory concentration: 860000 nM
Compound 4: middle estimate off by 3.4-fold (0.54 log units), on the low side; low and high end bracket the measured number.
By their numbers in this assay, from the lowest: compound 3; then compound 1; then compounds 4 and 2 (each within the scatter of the next).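

Exchanging the whole ring is not neutral: 3-methylthiophen-2-yl in place of phenyl on a carbon with a double bond to nitrogen raises the number (a 2.7-fold higher number from compound 1 to compound 4 (0.43 log units; beyond the scatter)), the same direction as the nitro step and the opposite of the bromo step. The new compound stands far from the bromo analogue (an 18-fold higher number from compound 3 to compound 4 (1.25 log units; beyond the scatter)) and cannot be told apart from the nitro analogue (a 1.1-fold lower number from compound 2 to compound 4 (0.05 log units; within the scatter)), so among the four compounds only the 3-bromophenyl group gives a number lower than that of the phenyl parent. No supporting data bear on why this exchange shifts the number.

The compounds shown do not separate the five-membered ring from its methyl group, and an unsubstituted thiophen-2-yl or a furan-2-yl on the same carbon would bear on that. Also open, on these data alone, is whether a bromo group on the thiophene ring, or an amine or a carboxylic acid on either ring, would bring the number near or below that of compound 3 (48000 nM).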